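The source may hold more compounds than are shown below. What is called first, only, known or untested is meant among the compounds shown, and "the series" means these compounds.

Of the compounds shown here, three have been measured in a physicochemical assay for lipophilicity; a higher number here means a more lipophilic compound, a lower number a more polar compound. Compound 1, with the structure `CC(C)=CCC/C(C)=C/CC/C(C)=C/CSC[C@H](NC(=O)CCCCCN1CCCC1)C(=O)NC1CCCCC1`, gives 4.48 in this assay. Compound 2, `CC(C)=CCC/C(C)=C/CC/C(C)=C/CSc1ccccc1C(N)=O`, gives 6.03, and compound 3, `CC(C)=CCC/C(C)=C/CC/C(C)=C/CSC[C@H](NC(=O)CCCCCN1CCN(C)CC1)C(=O)NC1CCCCCCC1`, gives 5.88. Compound 1 therefore stands lowest of the three numbers; the nearest is compound 3, which lies beyond the scatter above it, and compound 2 lies further above still. Compounds 2 and 3 each differ from compound 1 in more than one place, so their gaps to compound 1 cannot be tied to any single change.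

Compound 4, `CC(C)=CCC/C(C)=C/CC/C(C)=C/CSC[C@H](NC(=O)CCCCCN1CCCC1)C(=O)NC1CCCC1`, has not yet been measured in this assay. It differs from compound 1 in one place: cyclopentyl in place of cyclohexyl on an amide-type nitrogen. Going by the values given here, nothing among the measured compounds shows this change in isolation. Taking one carbon out of a ring of this kind is expected to move the number modestly downward, by a step of roughly a number 0.38 log units lower from compound 1 to compound 4 (beyond the scatter), close to the edge of the scatter. For compound 4 the estimate in this assay is 4.1, with a range from 3.7 to 4.5.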

Compound 4, distribution coefficient: 4.04
Estimate against measurement, compound 4: 0.06 log units above; low and high end bracket the measured number.
By their numbers in this assay, from the lowest: compound 4; then compound 1; then compounds 3 and 2 (each within the scatter of the next).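

Before compound 4, no two compounds measured in this assay differed in only one place, so no change could be tied to a single group. The change from cyclohexyl to cyclopentyl on the amide-type nitrogen now gives that first clean comparison, with a number 0.44 log units lower from compound 1 to compound 4 (beyond the scatter) showing that the number at this position responds to swapping the six-membered ring for the five-membered ring, even though neither group carries hydrogen-bond donors, acceptors or a net charge. Nothing available explains why the number moves.

The compounds shown leave open whether the number would keep falling with a cyclobutyl group, or how an open chain such as a butyl group or a polar group such as a hydroxyl on the ring would compare. A single pair also cannot show whether the same change would give a similar step on a different core.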